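This account rests on a few compounds, and the source may have more. Where it says the series, first, only, none or still open, it means among the compounds named here.

Compound 1, `CC(C)C(c1ccc(-c2ccc3cccc(F)c3c2)[nH]c1=O)N1CCN/C1=N\C#N`, is the shortest-lived of the compounds with a number in an ADME assay on microsomes from liver (Rattus norvegicus) for metabolic stability; on this read-out higher numbers stand for a longer-lived compound and lower numbers for a shorter-lived compound: compound 1 gives 0.327 h. Compound 2, `CCC(CC)(c1nnc[nH]1)c1ccc(-c2ccc3cccc(F)c3c2)[nH]c1=O`, gives 0.925 h in this assay, a value that lies beyond the scatter from that of compound 1. Compound 3, `CCn1ncc2c(F)cc(-c3ccc(C(CC)(CC)c4ncn(C)n4)c(=O)[nH]3)cc21`, reaches only a limit of this assay: compound 3 is reported as > 3 h. That limit is described as the limit of > 3 h in this assay, at which 1 of the 3 values shown sits.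

Compound 4, `CC(C)C(CC(N)=O)c1ccc(-c2ccc3cccc(F)c3c2)[nH]c1=O`, has not yet been measured in this assay. It differs from compound 1 in one place: a group of 4 heavy atoms (2 carbon, 1 nitrogen, 1 oxygen; no ring) in place of a group of 8 heavy atoms (4 carbon, 4 nitrogen; one five-membered non-aromatic ring with 2 hetero atoms), on a saturated chain carbon bound to an aromatic carbon and a saturated chain carbon. No measured pair in the set shows this change, so its effect on the half-life cannot be read from the data shown; the only anchor is the value of compound 1 itself.

He therefore expects a step from compound 1 to compound 4 of a 1.5-fold higher number from compound 1 to compound 4 (0.18 log units; within the scatter), within or at the edge of the scatter of this assay. Compound 4 is accordingly estimated at 0.5 h, in a range from 0.2 h to 1.2 h.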

Compound 4, half-life: < 0.0667 h
Compound 4: no number, only a limit; the forecaster's own chance of this, stated with the estimate: 5%; middle value at least 7.4-fold (0.87 log units) from the limit.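

In this assay, among the compounds shown here, carbamoylmethyl in place of the group with the five-membered non-aromatic ring, on a saturated chain carbon bound to an aromatic carbon and a saturated chain carbon, gives an at least 4.9-fold lower number from compound 1 to compound 4 (0.69 log units; beyond the scatter) and is the first step in the set that can be read at one place. Compound 4 gives a limit of the assay and not a number, so the step has a minimum size only: the limit of < 0.0667 h in this assay, at which 1 of the 4 values shown sits. The earlier compounds shown here offered no pair differing in one place, and this pair now shows that the half-life responds to the group held at this carbon.

As far as these compounds go, whether a carboxylic acid or a primary amine on this carbon would stay nearer compound 1 or compound 4 remains open. Also open, from the compounds shown here alone, is whether the same change would act alike on the core of compound 3.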